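The source may report more compounds than this note shows. Statements on the series, on what has been measured and on what is new or still open speak of the compounds shown alone.

Measured so far in an ADME assay on the whole organism for metabolic stability, with Rattus norvegicus as the target, at a dose of 10 mg/kg by the intraperitoneal route; on this read-out higher numbers stand for a longer-lived compound and lower numbers for a shorter-lived compound:

compound 1 `CCCC(=O)c1ccc(OCCCCOc2cc(C(=O)O)ccc2OC)c(C)c1O` gives 0.467 h
compound 2 `COc1ccc(C(=O)O)cc1OCCCCOc1ccc(C(=O)CC(C)C)c(O)c1C` gives 0.333 h
compound 3 `CCC(=O)c1ccc(OCCCCOc2ccc(F)c(C(=O)O)c2)c(C)c1O` gives 0.367 h

Compound 1 and compound 2 are joined by one change, (methyl in place of hydrogen on a saturated chain carbon bound to two saturated chain carbons), and the step it made was a 1.4-fold lower number from compound 1 to compound 2 (0.15 log units; within the scatter). Compound 3 carries a different core from compound 1; the difference between the two cores is not broken down here. Compound 3 sits close to compound 2 and to compound 1, all three within the usual scatter of one another, so no order among them is claimed.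

Not yet measured is compound 4 `Cc1c(OCCCCOc2ccc(F)c(C(=O)O)c2)ccc(C(=O)C(C)C)c1O`, which differs from compound 3 by methyl in place of hydrogen on a saturated chain carbon bound to a carbonyl carbon and a saturated chain carbon. Among the compounds with values here, this is the same kind of change as the one from compound 1 to compound 2, not the same: there the place was on a saturated chain carbon bound to two saturated chain carbons, here it is on a saturated chain carbon bound to a carbonyl carbon and a saturated chain carbon. Within the data shown here, because the only measured step of this kind is a 1.4-fold lower number from compound 1 to compound 2 (0.15 log units; within the scatter), the step in this assay is expected to be a 1.2-fold lower number from compound 3 to compound 4 (0.09 log units; within the scatter). The value expected for compound 4 is 0.3 h, with a range from 0.18 h to 0.5 h.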

Compound 4, half-life: 0.5 h
The estimate for compound 4 lay 1.7-fold (0.22 log units) below the measured number; measured number inside the range.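

Methyl in place of hydrogen on the chain carbon bound to a carbonyl carbon and a saturated chain carbon, read as propanoyl to isopropylcarbonyl, gives a 1.4-fold higher number from compound 3 to compound 4 (0.13 log units; within the scatter) in this assay. Set beside the earlier step of this kind, the two steps do not separate: the same change on two cores in this assay, a 1.4-fold lower number (0.15 log units; within the scatter) from compound 1 to compound 2 and a 1.4-fold higher number (0.13 log units; within the scatter) from compound 3 to compound 4, 1.9-fold (0.28 log units) apart, within the scatter of two such steps. Within the data shown here, this shows that, in these two pairs, adding a methyl to the acyl chain leaves the half-life within the scatter on either core; it does not show that the change carries over with a fixed size or direction, since there are only two steps, each inside the scatter, and they sit on different chain carbons.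

Open, on these data alone, is whether a larger group at this place, such as tert-butyl or a cyclohexyl ring, would give a step beyond the scatter. Also open, as far as these compounds go, is whether an amide or a tetrazole in place of the carboxylic acid would alter how this change reads in this assay.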